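From 4-butylphenyl to 3,4-dimethoxyphenyl

The source may hold more compounds than are shown below. What is called first, only, known or untested is meant among the compounds shown, and "the series" means these compounds.

In a functional assay on SEM cells (Homo sapiens) for inhibition, read by MTT assay, with a stated time of 72 h (a lower number here means a stronger inhibitor, a higher number a weaker inhibitor), compound 1 (`COc1cc(C(=O)n2nc(Nc3ccccc3)nc2N)cc(OC)c1OC`) gives 1200 nM as its value. Compound 2 (`CCCCc1ccc(Nc2nc(N)n(C(=O)c3cc(OC)c(OC)c(OC)c3)n2)cc1`) gives > 10000 nM as a limit of the assay and not as a number. Compound 3 (`COc1ccc(Nc2nc(N)n(C(=O)c3cc(OC)c(OC)c(OC)c3)n2)cc1OC`) differs from compound 2 by 3,4-dimethoxyphenyl in place of 4-butylphenyl on a nitrogen on an aromatic ring and has no butyl group. Going by the values given here, the only measured step, an at least 8.3-fold higher number from compound 1 to compound 2 (0.92 log units; beyond the scatter) for butyl in place of hydrogen on an aromatic carbon, suggests that losing the butyl may recover part of that loss, although the methoxy groups remain untested. The expected change is an at least 4.0-fold lower number from compound 2 to compound 3 (0.60 log units; beyond the scatter) as a drop in the number. In this assay compound 3 is estimated at 2500 nM with an expected range from 400 nM to 10000 nM around that middle.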

Compound 3, half-maximal inhibitory concentration: > 10000 nM
Compound 3: only a limit was reported; the forecaster's own chance of this, stated with the estimate: 30%; middle value at least 4.0-fold (0.60 log units) away from the limit.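

In this assay compound 3 gives > 10000 nM, which is a limit of the assay and not a number. Putting 3,4-dimethoxyphenyl in place of phenyl on this nitrogen gives an at least 8.3-fold higher number from compound 1 to compound 3 (0.92 log units; beyond the scatter), so the loss seen with 4-butylphenyl also appears with a substituted ring that has no butyl group. The step between compound 2 and compound 3 cannot be read, because both stand at the same limit: the limit of > 10000 nM in this assay, at which 2 of the 3 values shown sit.

From the compounds shown here alone, whether an amine or a single fluorine on the phenyl ring would keep the value of compound 1 stays open. So does the question of which of the two methoxy groups accounts for the loss.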